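A few compounds are considered here, and "the series" means these few. Any claim that something is new, unique, unknown or untested is made for them only; others in the source may bear on it.

Compounds measured so far:

- compound 1 `O=C(Nc1ccc(Nc2ncnc3c2OCCN3)cc1)Nc1ccc(C(F)(F)F)cc1` gives 2470 nM
- compound 2 `Cc1cc(C)cc(NC(=O)Nc2ccc(Nc3ncnc4c3OCCN4)cc2)c1` gives 3770 nM
- compound 3 `CC(C)(C)c1cc(NC(=O)Nc2ccc(Nc3ncnc4c3OCCN4)cc2)no1` gives 58 nM

In an assay on isolated protein for inhibition of proto-oncogene tyrosine-protein kinase receptor Ret variant V804L (Homo sapiens), read by 33P incorporation, with stated times of 15 min and 40 min (on this read-out lower numbers stand for stronger inhibition and higher numbers for weaker inhibition), compound 3 holds the lowest number of the three; the step of a 43-fold lower number from compound 1 to compound 3 (1.63 log units; beyond the scatter) and the step of a 65-fold lower number from compound 2 to compound 3 (1.81 log units; beyond the scatter) both lie beyond the scatter, while the step of a 1.5-fold higher number from compound 1 to compound 2 (0.18 log units; within the scatter) does not. Compound 4 `O=C(Nc1ccc(Nc2ncnc3c2OCCN3)cc1)Nc1cccs1` has not yet been measured. It differs from compound 3 in one place: thiophen-2-yl in place of 5-(tert-butyl)-1,2-oxazol-3-yl on an amide-type nitrogen.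

Going by the values given here, no measured step puts a thiophen-2-yl group on that nitrogen, so the bearing steps are indirect. Both steps into compound 3 show that replacing an aryl group on the amide-type nitrogen by the 5-(tert-butyl)-1,2-oxazol-3-yl group lowered the number by a large amount; compound 4 gives up that group for a smaller ring with no tert-butyl substituent. On those two steps, a move back toward the numbers of compound 1 and compound 2 is expected, likely beyond the scatter, though its size is uncertain. Compound 4 is therefore expected to give about 900 nM in this assay, with a range from 150 nM to 5000 nM, a step of a 16-fold higher number from compound 3 to compound 4 (1.19 log units; beyond the scatter).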

Compound 4, half-maximal inhibitory concentration: > 10000 nM
Compound 4: a limit, no number; the forecaster's own chance of this, stated with the estimate: 5%; at least 11-fold (1.04 log units) between middle value and limit.
By their numbers in this assay, from the lowest: compound 3; then compounds 1 and 2 (each within the scatter of the next). At a limit, above all of these: compound 4.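

In this assay, compound 4 gives only a limit, not a number: the limit of > 10000 nM in this assay, at which 1 of the 4 values shown sits. At the amide-type nitrogen, thiophen-2-yl in place of 5-(tert-butyl)-1,2-oxazol-3-yl gives an at least 170-fold higher number from compound 3 to compound 4 (2.23 log units; beyond the scatter), and the two aryl compounds also hold lower numbers, with an at least 2.6-fold higher number from compound 2 to compound 4 (0.42 log units; beyond the scatter) and an at least 4.0-fold higher number from compound 1 to compound 4 (0.60 log units; beyond the scatter). The earlier compounds shown here showed only that the 5-(tert-butyl)-1,2-oxazol-3-yl group gave a far lower number than two substituted phenyl groups; compound 3 and compound 4 now show that a five-membered aromatic ring on this nitrogen is not enough on its own.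

The compounds shown do not separate the contribution of the tert-butyl group from that of the 1,2-oxazole ring. Going by these compounds, how a 1,2-oxazol-3-yl group without tert-butyl, or a thiophen-2-yl group carrying tert-butyl, would read at this nitrogen remains open.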